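The source may hold more compounds than are shown below. What is called first, only, known or untested is meant among the compounds shown, and "the series" means these compounds.

Compound 1 `COc1ccc(-c2nc(/N=C(\N)N3CCOCC3)sc2-c2ccc(OC)cc2)cc1`: < 1000 nM (a limit)
Compound 2 `COc1ccc(-c2nc(CNC(=O)c3cccnc3)sc2-c2ccc(OC)cc2)cc1`: 25 nM
Compound 3 `COc1ccc(-c2nc(C(N)=O)sc2-c2ccc(OC)cc2)cc1`: not yet measured

Going by the values given here, in a functional assay with Oryctolagus cuniculus as the target (on this read-out lower numbers stand for stronger inhibition and higher numbers for weaker inhibition), compound 2 gives 25 nM, the only actual number. Compound 1 stands at < 1000 nM, which is a limit.

Compound 3 differs from compound 2 by carbamoyl in place of (((pyridin-3-yl)carbonyl)amino)methyl on an aromatic carbon. Among the compounds with values here, the one measured step, a step that the limit leaves unreadable from compound 1 to compound 2, exchanges the group on the same aromatic carbon, but it offers no size to carry over. With compound 2 at 25 nM as the sole anchor, weaker inhibition is expected, though its size is poorly defined. The expected step is an 8.0-fold higher number from compound 2 to compound 3 (0.90 log units; beyond the scatter). For compound 3 the estimated value is 200 nM, with an expected range of 25 nM to 2000 nM.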

Compound 3, half-maximal inhibitory concentration: > 1000 nM
Compound 3: a limit, no number (the forecaster's own chance of this, stated with the estimate: 15%); middle value at least 5.0-fold (0.69 log units) away from the limit.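

In this assay, going by these compounds alone, carbamoyl in place of (((pyridin-3-yl)carbonyl)amino)methyl on this aromatic carbon gives an at least 40-fold higher number from compound 2 to compound 3 (1.60 log units; beyond the scatter), the first step of readable size at this position, and it shows that the 25-range inhibition of the larger group does not persist in the short primary amide. Compound 3 is read as a limit, not a number: the limit of > 1000 nM in this assay, at which 1 of the 3 values shown sits. The remaining step, a number no lower from compound 1 to compound 3 (the limit leaves the size open), cannot be read.

On these data alone, what remains open is whether the gap follows the pyridin-3-yl ring or the chain. A phenyl group in place of that ring, or a plain aminomethyl group on this carbon, would separate the two.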